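Hexyl to propyl on the hydrazide of compound 1

The source may report more compounds than this note shows. Statements on the series, on what has been measured and on what is new or still open speak of the compounds shown alone.

For the measured compounds named here, compound 1 `CCCCCCNNC(=O)c1ccc(-c2ccc(CNC(C)=O)cc2)cc1` gives 180 nM in an assay on isolated protein for inhibition of histone deacetylase 11 (Homo sapiens), read by fluorescence, with a stated time of 10 min (on this read-out higher numbers stand for weaker inhibition and lower numbers for stronger inhibition), the higher of the two numbers known so far; compound 2 `CCCCCCNNC(=O)c1cnc(N2CCN(Cc3c[nH]c4ccccc34)CC2)nc1` gives 41 nM in this assay, a gap beyond the usual scatter. Compound 3 `CCCNNC(=O)c1ccc(-c2ccc(CNC(C)=O)cc2)cc1` differs from compound 1 by hydrogen in place of propyl on a saturated chain carbon, three bonds along the chain from an amine nitrogen. Going by the values given here, no measured pair shows this change, so its size is open. Shortening the chain here is expected to weaken inhibition, a step of an 8.3-fold higher number from compound 1 to compound 3 (0.92 log units; beyond the scatter) larger than the scatter. Compound 3 is therefore expected to give about 1500 nM, between 400 nM and 6000 nM.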

Compound 3, half-maximal inhibitory concentration: 1800 nM
Compound 3: middle estimate off by 1.2-fold (0.08 log units), on the low side; low and high end bracket the measured number.
By their numbers in this assay, from the lowest: compound 2; then compound 1; then compound 3.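

Cutting the hydrazide chain from hexyl to propyl gives the first single-change read at this position: in this assay, the step is a 10-fold higher number from compound 1 to compound 3 (1.00 log units; beyond the scatter) on the core of compound 1. The change removes only saturated carbon, with no hydrogen-bond donor, acceptor or net charge entering or leaving, yet inhibition weakens beyond the scatter. Nothing available explains this loss.
Still open, on these data alone, is how butyl and pentyl chains fall within this step, and whether a heptyl chain goes further. Whether the same change carries over to the core of compound 2 is also unresolved.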